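The compounds below may be only part of what the source reports. "The series", "measured", "known", "first", "only" and "open" are said of these compounds alone.

Measured compounds:
- compound 1: `NC(=S)N/N=C/c1ccc2ccccc2n1` — 960 nM
- compound 2: `Fc1ccccc1NC(=S)N/N=C/c1ccc2ccccc2n1` — > 100000 nM
- compound 3: `S=C(N/N=C/c1ccc2ccccc2n1)Nc1ccc(Cl)cc1` — > 100000 nM

In a functional assay on HeLa cells (Homo sapiens) for antiproliferative activity, read by sulforhodamine B assay, with a stated time of 72 h (a lower number here means a stronger inhibitor, a higher number a weaker inhibitor), compound 1 gives 960 nM. For compound 2 the assay reports only a limit, > 100000 nM. For compound 3 it likewise reports only a limit, > 100000 nM. Compound 3 thus stands at the limit of > 100000 nM in this assay, at which 2 of the 3 values shown sit, and the step that the two limits leave unreadable from compound 2 to compound 3 stays unreadable.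

Compound 4, `COc1ccc(NC(=S)N/N=C/c2ccc3ccccc3n2)cc1`, differs from compound 3 by methoxy in place of chloro on an aromatic carbon. The measured steps that bear on this are an at least 100-fold higher number from compound 1 to compound 2 (2.01 log units; beyond the scatter) and an at least 100-fold higher number from compound 1 to compound 3 (2.01 log units; beyond the scatter): placing 2-fluorophenyl or 4-chlorophenyl on the amide-type nitrogen in place of hydrogen drove the number past the limit in both cases. Compound 4 keeps such a group on that nitrogen, with only the para substituent exchanged, so the expected step is a number no higher from compound 3 to compound 4 (the limit leaves the size open), that is, no readable change from a compound already at the limit. Compound 4 is therefore expected to give 100000 nM, in the range 30000 nM to 300000 nM, most likely again reported only as a limit.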

Compound 4, half-maximal inhibitory concentration: 72600 nM
Compound 4: middle estimate off by 1.4-fold (0.14 log units), on the high side; the range from low to high includes it.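

In this assay, compound 4 is the only one of the three phenyl-bearing compounds to give a number rather than a limit, so the cost of such a group on the amide-type nitrogen can now be given a size: a 76-fold higher number from compound 1 to compound 4 (1.88 log units; beyond the scatter). Methoxy in place of chloro gives an at least 1.3-fold lower number from compound 3 to compound 4 (0.13 log units; that floor lies within the scatter), and 4-methoxyphenyl in place of 2-fluorophenyl gives an at least 1.3-fold lower number from compound 2 to compound 4 (0.13 log units; that floor lies within the scatter); both floors lie within the scatter, so neither shows a real gain. The change on the aromatic carbon therefore recovers little of what the phenyl group cost, and the other two phenyl-bearing compounds remain limits: the limit of > 100000 nM in this assay, at which 2 of the 4 values shown sit.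

The compounds shown leave open whether a methyl or ethyl group on that nitrogen would keep the number closer to that of compound 1. They also leave open what an amine or a carboxylic acid would do on the same aromatic carbon.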